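Taking the bromo group off compound 3

A few compounds are considered here, and "the series" means these few. Any claim that something is new, unique, unknown or untested is made for them only; others in the source may bear on it.

Values in a functional assay on the whole organism with Mus musculus as the target; a higher number here means that more compound is needed for the effect, a lower number that less compound is needed
compound 1 `COc1cc2c(cc1OC)C(c1cccc(N)c1)=NN=C(S)C2` gives 18.8 umol/kg
compound 2 `COc1cc2c(cc1OC)C(c1ccc(N)cc1)=NN=C(S)C2` gives 6.3 umol/kg
compound 3 `COc1cc2c(cc1OC)C(c1ccc(Br)cc1)=NN=C(S)C2` gives 52.1 umol/kg

Of these three, compound 3 has the highest number, so it needs the most compound for the effect. Compound 4 `COc1cc2c(cc1OC)C(c1ccccc1)=NN=C(S)C2` has hydrogen in place of bromo on an aromatic carbon. The nearest evidence is the exchange of amino for bromo at that same place (an 8.3-fold higher number from compound 2 to compound 3 (0.92 log units; beyond the scatter)), and the change of the amino-bearing ring also counts (a 3.0-fold lower number from compound 1 to compound 2 (0.47 log units; beyond the scatter)). Going by the values given here, no measured compound carries hydrogen there, so the direction is only weakly supported. For compound 4 a small step toward a lower number is expected in this assay (a 1.7-fold lower number from compound 3 to compound 4 (0.24 log units; within the scatter)). The estimate for compound 4 is 30 umol/kg (expected range 12 umol/kg to 75 umol/kg).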

Compound 4, dose for half-maximal effect: 19.7 umol/kg
Compound 4: the middle estimate sits 1.5-fold (0.18 log units) above what was measured; measured number inside the range.
By their numbers in this assay, from the lowest: compound 2; then compounds 1 and 4 (each within the scatter of the next); then compound 3.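

Hydrogen at this place on the ring needs less compound than bromo in this assay (a 2.6-fold lower number from compound 3 to compound 4 (0.42 log units; beyond the scatter)), so the bromo group is a drawback here rather than a neutral addition. The unsubstituted ring also gives a baseline, showing that the amino group of compound 2 is a real gain over hydrogen (a 3.1-fold higher number from compound 2 to compound 4 (0.50 log units; beyond the scatter)). The amino group sitting elsewhere on the ring in compound 1 gives no such gain (a 1.0-fold higher number from compound 1 to compound 4 (0.02 log units; within the scatter)).

On these data alone, whether a methoxy group or a carboxylic acid at this place would match the amino group stays open. Nothing available explains these differences.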